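The source may hold more compounds than are shown below. What is called first, only, known or untested is meant among the compounds shown, and "the series" means these compounds.

Measured so far:
Compound 1, `O=C(C1CCN(c2ccncn2)CC1)N1N=CC[C@H]1c1ccccc1`, gives 3.3 h in an ADME assay on cells (Hepatocyte, Homo sapiens) for metabolic stability; on this read-out higher numbers stand for a longer-lived compound and lower numbers for a shorter-lived compound.
Compound 2, `O=C(C1CCN(c2cccnn2)CC1)N1N=CC[C@H]1c1ccccc1`, gives 2.32 h.
Compound 3, `CC(=O)N1CCC(C(=O)N2N=CC[C@H]2c2ccccc2)CC1`, gives > 3.11 h.

The figure for compound 3 is a limit of this assay rather than a number, as the limit of > 3.11 h in this assay, at which 1 of the 3 values shown sits, records. Compound 4, `O=C(C1CCN(c2ccccn2)CC1)N1N=CC[C@H]1c1ccccc1`, differs from compound 3 in one place: pyridin-2-yl in place of acetyl on an amine nitrogen in a ring. Among the measured compounds shown here, two measured steps concern the same position. The step that the limit leaves unreadable from compound 1 to compound 3 cannot be read. The step of an at least 1.3-fold higher number from compound 2 to compound 3 (0.12 log units; that floor lies within the scatter) is known only by its floor. Between the two aromatic rings already measured, a 1.4-fold lower number from compound 1 to compound 2 (0.15 log units; within the scatter). Nothing here points to a shift beyond the scatter. The step of an at least 1.0-fold lower number from compound 3 to compound 4 (0.03 log units; that floor lies within the scatter) is therefore expected. In this assay compound 4 is estimated at 2.9 h, with a range from 1.6 h to 5.5 h.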

Compound 4, half-life: > 3.11 h
Compound 4: only a limit was reported; the forecaster's own chance of this, stated with the estimate: 20%; middle value at least 1.0-fold (0.03 log units) away from the limit.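

Compound 4 gives > 3.11 h, which is a limit of this assay and not a number. Among the compounds shown here, the only readable step is an at least 1.3-fold higher number from compound 2 to compound 4 (0.12 log units; that floor lies within the scatter), so this change shows no clear difference between pyridin-2-yl and pyridazin-3-yl on this ring nitrogen. The steps to compound 4 from compound 1 and compound 3 cannot be read, and a second group, aromatic this time, now stands at the same limit: the limit of > 3.11 h in this assay, at which 2 of the 4 values shown sit.

From the compounds shown here alone, how long compound 3 and compound 4 really last stays open. So does how a plain phenyl ring or a longer acyl chain would fare on this nitrogen.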